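Amide variation on a dimethoxy bicyclic acetamide series

The source may report more compounds than this note shows. Statements on the series, on what has been measured and on what is new or still open speak of the compounds shown alone.

Compound 1 `COc1cc2c(cc1OC)C(CC(N)=O)CC2` carries a primary amide on the shared core. In a functional assay on the whole organism (strain Wistar) for inhibition, with Rattus norvegicus as the target, read by paw edema, with stated times of 60 min and 6 h, at a dose of 100 mg/kg by the oral route (a lower number here means less inhibition, a higher number more inhibition at the dose given (going by the name of the read-out)), compound 1 gives 27.8%. Compound 2 `CCCNC(=O)CC1CCc2cc(OC)c(OC)cc21` carries a propyl group on the amide-type nitrogen in place of hydrogen, and in this assay compound 2 gives 22.2%. Among the compounds with values here, the one measured step, a number 5.6 percentage points lower from compound 1 to compound 2 (within the scatter), stays within the scatter, so compound 2 stands on level with compound 1, the only other number available, and no order between them can be read.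

Compound 3 `COc1cc2c(cc1OC)C(CC(=O)N1CCNCC1)CC2` is the next member: piperazin-1-yl in place of propylamino on a carbonyl carbon. The step from compound 2 to compound 3 changes the same carbonyl carbon that the step from compound 1 to compound 2 already changed, so that step is the only one that bears on it, and it was small. With a single step, and that one within the scatter, the expectation for compound 3 is no step beyond the scatter in this assay, estimated as a number 1.8 percentage points higher from compound 2 to compound 3 (within the scatter). Compound 3 is therefore expected to give about 24% in this assay, in the range 10% to 38%.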

Compound 3, a percentage reported as inhibition, in the whole organism at one dose (the size of the read-out at that dose, not a potency): 33.3%
Compound 3: middle estimate off by 9.3 percentage points, on the low side, and the stated range covers the measured number.
By their numbers in this assay, from the lowest: compounds 2, 1 and 3 (each within the scatter of the next, the first and the last beyond it).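

At the carbonyl carbon, in this assay, piperazin-1-yl in place of propylamino gives the only step beyond the scatter among these compounds, a number 11.1 percentage points higher from compound 2 to compound 3 (beyond the scatter), so the group on this carbon can separate two members of the series, which the step from compound 1 to compound 2 did not show. The separation does not hold against the primary amide: piperazin-1-yl in place of amino gives a number 5.5 percentage points higher from compound 1 to compound 3 (within the scatter), so compound 1 cannot be ordered against either compound 2 or compound 3, and the ring amide is set apart from the propyl amide alone. Nothing measured here accounts for the step between compound 2 and compound 3.

The compounds shown leave open whether the step goes with the ring itself or with the nitrogens in it, a question that a piperidine or morpholine amide on the same carbonyl carbon would address. Also open, on these data alone, is how a carboxylic acid in place of the amide, or a longer chain on the amide nitrogen, would read in this assay at this one dose.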